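The source may hold more compounds than are shown below. What is called first, only, known or untested is meant among the compounds shown, and "the series" means these compounds.

Measured compounds:
Compound 1 `COc1ccc(C(=O)/C=C/c2cc(-c3cc(OC)c(OC)c(OC)c3)n3nc(-c4ccccc4)cc3n2)cc1OC` gives 18300 nM in a functional assay on MDA-MB-231 cells (Homo sapiens) for antiproliferative activity, read by MTT assay, with a stated time of 24 h; on this read-out lower numbers stand for stronger inhibition and higher numbers for weaker inhibition.
Compound 2 `COc1ccc(-c2cc(/C=C/C(=O)c3ccccc3)nc3cc(-c4ccccc4)nn23)cc1OC` gives 11800 nM in this assay.
Compound 3 `COc1cc(-c2cc(/C=C/C(=O)c3ccc(C)cc3)nc3cc(-c4ccccc4)nn23)cc(OC)c1OC` gives 23900 nM in this assay.

Compound 3 holds the highest number of the three. Among the compounds with values here, its gap to compound 1 is the step of a 1.3-fold higher number from compound 1 to compound 3 (0.12 log units; within the scatter), and compound 2 sits at a lower number than compound 3, a gap beyond the scatter; no single-change step connects compound 2 and compound 3.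

The next compound is compound 4 `COc1cc(-c2cc(/C=C/C(=O)c3ccccc3)nc3cc(-c4ccccc4)nn23)cc(OC)c1OC`. Its difference from compound 3 is hydrogen in place of methyl on an aromatic carbon. Within the data shown here, the only measured step on the same end of the molecule is the one from compound 1 to compound 3, where a change of the whole aryl group on the carbonyl carbon left the number within the scatter. Removing one methyl is a smaller change than that, so no step beyond the scatter is expected in this assay; the estimated step is a 1.2-fold lower number from compound 3 to compound 4 (0.08 log units; within the scatter). Compound 4 is therefore expected at about 20000 nM, with a range from 9000 nM to 45000 nM.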

Compound 4, half-maximal inhibitory concentration: 15800 nM
Beside the measured number, compound 4's estimate is 1.3-fold (0.10 log units) above it; the measured number falls inside the stated range.
By their numbers in this assay, from the lowest: compounds 2, 4, 1 and 3 (each within the scatter of the next, the first and the last beyond it).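

On the carbonyl side, in this assay, hydrogen in place of methyl gives a 1.5-fold lower number from compound 3 to compound 4 (0.18 log units; within the scatter) and phenyl in place of 3,4-dimethoxyphenyl gives a 1.2-fold lower number from compound 1 to compound 4 (0.06 log units; within the scatter), so compound 1, compound 3 and compound 4 show no step beyond the scatter across these three aryl groups on the carbonyl carbon. Within the data shown here, compound 4 also gives the first single-change step on the other aryl group, where methoxy in place of hydrogen gives a 1.3-fold higher number from compound 2 to compound 4 (0.13 log units; within the scatter), and it links compound 2 and compound 3, whose gap beyond the scatter is thus made up of two steps within it. No measurement at hand gives a reason for these steps.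

Still open, as far as these compounds go, is whether an amine or a carboxylic acid on the aryl group at the carbonyl carbon would move the number beyond the scatter. The same question stands for a longer chain in place of a methoxy group on the other aryl group.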